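The source may hold more compounds than are shown below. What is called first, only, known or untested is meant among the compounds shown, and "the series" means these compounds.

Three compounds from this series have been examined in an ADME assay on MDCK cells (Canis lupus familiaris) for cytotoxicity, read by microscopy, with a stated time of 48 h; on this read-out lower numbers stand for higher toxicity in this test and higher numbers for lower toxicity in this test. Compound 1 `Cc1ccsc1CN[C@@H]1C[C@H]2C[C@@H]([C@H]1C)C2(C)C` gives 10000 nM. Compound 2 `C=C(C)c1csc(CN[C@@H]2C[C@H]3C[C@@H]([C@H]2C)C3(C)C)c1` gives 25000 nM, and compound 3 `C[C@H]1[C@H](NCc2ccc(Cl)s2)C[C@H]2C[C@@H]1C2(C)C` gives 25000 nM. On these numbers compound 2 stands level with compound 3 at the digits shown, the two of them together at the top of the three, while compound 1 sits apart: a 2.5-fold higher number from compound 1 to compound 3 (0.40 log units; beyond the scatter).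

Compound 4 `C[C@H]1[C@H](NCc2cc(C3CCCC3)cs2)C[C@H]2C[C@@H]1C2(C)C` is not yet measured. It differs from compound 2 in one place, (cyclopentyl in place of 1-methylethenyl on an aromatic carbon). Among the measured compounds shown here, the only measured step, from compound 1 to compound 3, also swaps a group on the five-membered aromatic ring, and it was modest. For the measured compounds named here, no measured step changes the group at this particular ring position, so that step bears on the question only loosely. Given that both substituted variants so far stay near the top, the step of no change at the digits printed from compound 2 to compound 4 (within the scatter) is expected to lie within the scatter. Compound 4 is therefore expected to give about 25000 nM, within a range from 10000 nM to 60000 nM.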

Compound 4, minimum cytotoxic concentration: 1560 nM
Compound 4: middle estimate off by 16-fold (1.20 log units), on the high side, and the stated range ends above it.
By their numbers in this assay, from the lowest: compound 4; then compound 1; then compounds 2 and 3 (each within the scatter of the next).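

The ring carbon two ring bonds from the ring sulfur proves sensitive in this assay: replacing 1-methylethenyl with cyclopentyl there moves the number sharply downward, towards higher toxicity in this test (a 16-fold lower number from compound 2 to compound 4 (1.20 log units; beyond the scatter)). Among the compounds shown here, the only earlier step (a 2.5-fold higher number from compound 1 to compound 3 (0.40 log units; beyond the scatter)) was modest and did not vary the group at this position, so it gave no sign that a change here could matter this much. Nothing on hand accounts for the size of this drop.

The compounds shown do not separate the presence of the saturated ring from the larger number of carbons in the group, nor from the loss of the double bond. As far as these compounds go, it also remains open whether an open-chain pentyl group, a phenyl ring or a cyclopropyl ring at this position would give a similarly low number.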